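This account rests on a few compounds, and the source may have more. Where it says the series, first, only, none or still open, it means among the compounds named here.

In a functional assay on the whole organism for inhibition, with Rattus norvegicus as the target, read by paw edema, in the formalin test, with a stated time of 4 h, at a dose of 100 mg/kg by the intraperitoneal route (on this read-out higher numbers stand for more inhibition at the one dose given (going by the name of the read-out) and lower numbers for less inhibition), two compounds have been measured so far. Compound 1, with the structure `O=c1cc(CNc2nc(-c3cc4cc(Br)cc(Br)c4oc3=O)cs2)c2cc(Cl)ccc2[nH]1`, gives 29.8%. Compound 2, with the structure `Cc1cccc2c(CNc3nc(-c4cc5cc(Br)ccc5oc4=O)cs3)cc(=O)[nH]c12`, gives 14.5%. Compound 2 therefore stands lowest of the two numbers in this assay; its nearest neighbour is compound 1, whose value lies higher by a gap that goes beyond the usual scatter of repeated measurements.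

The step under consideration leads from compound 2 to compound 3, whose structure is `Cc1cccc2c(CNc3nc(-c4cc5cc(Br)cc(Br)c5oc4=O)cs3)cc(=O)[nH]c12`. The change is bromo in place of hydrogen on an aromatic carbon. Among the compounds with values here, no step between two measured compounds that differ only in this one place is available, so the size of the step cannot be read off from a measured pair.

The expectation for the step from compound 2 to compound 3 in this assay is a small rise, an expected a number 5.5 percentage points higher from compound 2 to compound 3 (within the scatter), which would remain within the scatter. Within the data shown here, the only guide to the direction is compound 1, whose value 29.8% is the higher of the two numbers known. On this basis compound 3 is estimated to give 20% in this assay, with a range from 8% to 34%.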

Compound 3, a percentage reported as inhibition, in the whole organism at one dose (the size of the read-out at that dose, not a potency): 22.7%
For compound 3 the middle estimate is 2.7 percentage points below the measured one; the measured number falls inside the stated range.
By their numbers in this assay, from the lowest: compounds 2, 3 and 1 (each within the scatter of the next, the first and the last beyond it).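

Within the data shown here, compound 3 supplies the first measured pair that differs only at this place: in this assay, bromo in place of hydrogen on an aromatic carbon, ortho to a fused ring and meta to a bromo group, reads as a number 8.2 percentage points higher from compound 2 to compound 3 (within the scatter). The read-out at the one dose given therefore does not separate the two compounds, and this single pair shows that the position accepts a bromo group without a change beyond the scatter, but it cannot be called a gain or a loss. Nothing available speaks to the reason for this result.

On these data alone, whether a different group on this same aromatic carbon, such as methoxy, an amine or a carboxylic acid, would move the number beyond the scatter remains open. Among these compounds, also open is whether the bromo step would read the same in a compound without the methyl group, since compound 1 differs from compound 3 in more than one place and so gives no step for this change.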